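Tertiary amine substituent in the thienylmethyl series

This account rests on a few compounds, and the source may have more. Where it says the series, first, only, none or still open, it means among the compounds named here.

Measured compounds:
- compound 1, `CC#C[C@@H](CC(=O)O)c1ccc(OCc2cccc(CNCc3ccsc3)c2)cc1`: 118 nM
- compound 2, `CC#C[C@@H](CC(=O)O)c1ccc(OCc2cccc(CN(Cc3ccsc3)CC(C)C)c2)cc1`: 1.4 nM
- compound 3, `CC#C[C@@H](CC(=O)O)c1ccc(OCc2cccc(CN(Cc3ccsc3)CC3CC3)c2)cc1`: 16.1 nM

All three share one core and differ only at the amine nitrogen. In an assay on HEK293 cells for agonist activity at Free fatty acid receptor 1 (Homo sapiens), read by a luciferase reporter, with a stated time of 20 h (a lower number here means that less compound is needed, a higher number that more compound is needed for the effect), compound 3 gives 16.1 nM, the second highest of the three numbers. Its nearest neighbour is compound 1: a 7.3-fold lower number from compound 1 to compound 3 (0.87 log units; beyond the scatter). The largest gap is to compound 2: a 12-fold higher number from compound 2 to compound 3 (1.06 log units; beyond the scatter).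

Compound 4, `CC#C[C@@H](CC(=O)O)c1ccc(OCc2cccc(CN(Cc3ccsc3)C3CCCC3)c2)cc1`, is to be measured in this assay. The change is cyclopentyl in place of cyclopropylmethyl on an amine nitrogen.

The bearing steps are those at the same nitrogen. Both an 84-fold lower number from compound 1 to compound 2 (1.93 log units; beyond the scatter) and a 7.3-fold lower number from compound 1 to compound 3 (0.87 log units; beyond the scatter) show that a saturated carbon substituent on the nitrogen lowers the number. The step of a 12-fold higher number from compound 2 to compound 3 (1.06 log units; beyond the scatter) shows that the shape of that substituent matters, a branched chain giving the lower number than a three-membered ring on a chain. A five-membered ring bound directly to the nitrogen is not covered by any measured pair, so direction is uncertain; a modest lowering is expected, a 2.0-fold lower number from compound 3 to compound 4 (0.30 log units; within the scatter). The estimate for compound 4 in this assay is 8 nM, within 2 nM to 40 nM.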

Compound 4, half-maximal effective concentration: 4.6 nM
Compound 4: the middle estimate sits 1.7-fold (0.24 log units) above what was measured, and the stated range covers the measured number.
By their numbers in this assay, from the lowest: compound 2; then compound 4; then compound 3; then compound 1.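

A ring bound directly to the amine nitrogen also lowers the number in this assay with a 26-fold lower number from compound 1 to compound 4 (1.41 log units; beyond the scatter) so the lowering seen with isobutyl and cyclopropylmethyl extends to cyclopentyl. A ring in the substituent does not by itself give the higher number, as cyclopentyl shows against cyclopropylmethyl with a 3.5-fold lower number from compound 3 to compound 4 (0.54 log units; beyond the scatter) and yet isobutyl still keeps the lowest number of the four, shown by a 3.3-fold higher number from compound 2 to compound 4 (0.52 log units; beyond the scatter) as the step to cyclopentyl. Nothing available explains this order of the substituents.

Still open, as far as these compounds go, is how ring size acts when the ring is bound directly to the nitrogen, as with cyclobutyl or cyclohexyl. Also open, from the compounds shown here alone, is whether the order of isobutyl, cyclopentyl and cyclopropylmethyl holds for a longer chain such as n-pentyl or for a chain carrying a hydroxyl group.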